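This account rests on a few compounds, and the source may have more. Where it says the series, first, only, none or still open, it means among the compounds named here.

Compound 1 `CS(=O)(=O)OC1CCC(CN2CCN(c3cc(=O)c4cc(C(F)(F)F)cc([N+](=O)[O-])c4s3)CC2)CC1`: in an ADME assay on Vero cells (Chlorocebus sabaeus) for cytotoxicity, read by MTT assay, with a stated time of 48 h (a higher number here means a weaker inhibitor, a lower number a stronger inhibitor), compound 1 gives > 64 ug/mL, which is a limit of the assay and not a number.
Compound 2 `O=C(OC1CCC(CN2CCN(c3cc(=O)c4cc(C(F)(F)F)cc([N+](=O)[O-])c4s3)CC2)CC1)c1ccncc1`: in this assay compound 2 gives > 64 ug/mL, again a limit.
Compound 3 `Cc1ccc(C(=O)OC2CCC(CN3CCN(c4cc(=O)c5cc(C(F)(F)F)cc([N+](=O)[O-])c5s4)CC3)CC2)cc1`: in this assay compound 3 gives > 64 ug/mL, also a limit.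

Compound 1 therefore stands only at a limit in this assay, and the two other values shown are limits as well (the limit of > 64 ug/mL in this assay, at which 3 of the 3 values shown sit). Compound 4 `COc1ccccc1C(=O)OC1CCC(CN2CCN(c3cc(=O)c4cc(C(F)(F)F)cc([N+](=O)[O-])c4s3)CC2)CC1` has not yet been measured in this assay. It differs from compound 1 in one place ((2-methoxyphenyl)carbonyl in place of methylsulfonyl on an oxygen on a saturated carbon). The measured steps that bear on this change are a step that the two limits leave unreadable from compound 1 to compound 2 and a step that the two limits leave unreadable from compound 1 to compound 3, both of which replace the methylsulfonyl on the same oxygen with a carbonyl bearing an aromatic ring, and a step that the two limits leave unreadable from compound 2 to compound 3, which swaps one such ring for another; none of the three can be read in size, since both ends sit at the limit. Nothing in these data points to a readable step in this assay in either direction for compound 4, so the expected step is estimated as a step that the limit leaves unreadable from compound 1 to compound 4. Compound 4 is therefore expected to give about 90 ug/mL in this assay, within a range from 40 ug/mL to 250 ug/mL, most likely reported again as a limit.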

Compound 4, half-maximal inhibitory concentration: > 64 ug/mL
Compound 4 was reported as a limit; the forecaster's own chance of this, stated with the estimate: 85%; the middle value does not contradict the limit.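

The steps from compound 1, compound 2 and compound 3 to compound 4 cannot be read in size in this assay, because every value here is a limit and not a number: the limit of > 64 ug/mL in this assay, at which 4 of the 4 values shown sit. The compounds shown leave open whether the groups on this oxygen differ at all in this assay.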